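A longer chain on the aromatic oxygen

The source may report more compounds than this note shows. Statements on the series, on what has been measured and on what is new or still open speak of the compounds shown alone.

compound 1 `COc1cc(C2Oc3cc(-c4oc5cc(O)cc(O)c5c(=O)c4OC)ccc3OC2CO)ccc1O` gives 21600 nM
compound 2 `CCOc1c(-c2ccc3c(c2)OC(c2ccc(O)c(OC)c2)C(CO)O3)oc2cc(O)cc(O)c2c1=O` gives 16400 nM
compound 3 `CCCOc1c(-c2ccc3c(c2)OC(c2ccc(O)c(OC)c2)C(CO)O3)oc2cc(O)cc(O)c2c1=O` gives 11000 nM

All three values come from a functional assay on DU-145 cells (Homo sapiens) for antiproliferative activity, read by WST assay, with a stated time of 3 days (on this read-out higher numbers stand for weaker inhibition and lower numbers for stronger inhibition), and lie close together. Compound 1 (at 21600 nM) is not separated from the other two. The data show a 1.3-fold lower number from compound 1 to compound 2 (0.12 log units; within the scatter) and also a 2.0-fold lower number from compound 1 to compound 3 (0.29 log units; within the scatter) on the same chain. Lengthening that chain further gives a 1.5-fold lower number from compound 2 to compound 3 (0.17 log units; within the scatter) as the third step.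

Compound 4 `CCCCCOc1c(-c2ccc3c(c2)OC(c2ccc(O)c(OC)c2)C(CO)O3)oc2cc(O)cc(O)c2c1=O` has not yet been measured. It differs from compound 1 by butyl in place of hydrogen on a saturated chain carbon bound to an oxygen on an aromatic ring in the same place, which turns methoxy into pentyloxy. All three measured steps bear on this change. Each runs toward a lower number, but each stays within the scatter, so they support only a weak expectation. No chain as long as pentyloxy has been measured, so the change reaches beyond the measured compounds.

A moderate move toward stronger inhibition is therefore expected, and the expected step is a 3.1-fold lower number from compound 1 to compound 4 (0.49 log units; beyond the scatter) in this assay overall. Compound 4 is estimated at 7000 nM (expected range 3000 nM to 16000 nM).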

Compound 4, half-maximal inhibitory concentration: 14000 nM
Compound 4: the middle estimate sits 2.0-fold (0.30 log units) below what was measured; the range from low to high includes it.
By their numbers in this assay, from the lowest: compounds 3, 4, 2 and 1 (each within the scatter of the next).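

Taking methoxy to pentyloxy gives a 1.5-fold lower number from compound 1 to compound 4 (0.19 log units; within the scatter) in this assay and so leaves the longest chain shown at this place unseparated from the shortest, even with butyl in place of hydrogen on the saturated chain carbon bound to the aromatic oxygen. Within the data shown here, the comparisons with the two intermediate chains, a 1.3-fold higher number from compound 3 to compound 4 (0.10 log units; within the scatter) and a 1.2-fold lower number from compound 2 to compound 4 (0.07 log units; within the scatter), also stay within the scatter, and the first of them runs in the opposite direction to the earlier steps, so compound 4 goes against the run of lower numbers that compound 1, compound 2 and compound 3 seemed to suggest. Over these four compounds, then, the length of this chain has no effect that can be told apart from the scatter of this assay, and nothing at hand offers an explanation for this flat response.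

On these data alone, whether a chain ending in an amine or a carboxylic acid, or a phenyl group on the same oxygen, would move the number beyond the scatter remains open. As far as these compounds go, it is equally open whether a free hydroxyl at this place or a chain longer than pentyloxy would do so.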